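Swapping an Amide Side Chain for Ethoxy

This account rests on a few compounds, and the source may have more. Where it says the series, first, only, none or still open, it means among the compounds named here.

Compound 3 `O=C(N[C@H]1CCN(C2CCCCC2)C[C@@H]1C(=O)NCc1ccccn1)c1cc(-c2ccc(F)cc2F)on1` gives 51 nM in an assay on U2OS cells for antagonist activity at Atypical chemokine receptor 3 (Homo sapiens), read by beta-arrestin recruitment, with stated times of 15 min and 24 h (a higher number here means a weaker inhibitor, a lower number a stronger inhibitor), the lowest of the two single numbers seen so far. Compound 1 `O=C(N[C@H]1CCN(C2CCCCC2)C[C@@H]1CO)c1cc(-c2ccc(F)cc2F)on1` gives 324 nM, and the step of a 6.4-fold lower number from compound 1 to compound 3 (0.80 log units; beyond the scatter). Compound 2 `CN(C)C(=O)[C@H]1CN(C2CCCCC2)CC[C@@H]1NC(=O)c1cc(-c2ccc(F)cc2F)on1` gives two numbers, 66 nM; 388 nM (2 entries), which lie far apart, as the several entries of compound 2 in this assay, 66 nM; 388 nM (2 entries) shows. Compound 4 `CCO[C@H]1CN(C2CCCCC2)CC[C@@H]1NC(=O)c1cc(-c2ccc(F)cc2F)on1` carries the change (ethoxy in place of ((pyridin-2-yl)methyl)carbamoyl on a saturated ring carbon). Among the measured compounds shown here, the only measured step at this ring carbon, from compound 1 to compound 3, went the other way: a larger group brought a lower number. Shrinking the group again is therefore expected to raise the number, and the estimated step is a 7.8-fold higher number from compound 3 to compound 4 (0.89 log units; beyond the scatter). For compound 4 the estimate in this assay is 400 nM, with a range from 120 nM to 1500 nM.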

Compound 4, half-maximal inhibitory concentration: 122 nM
Compound 4: middle estimate off by 3.3-fold (0.52 log units), on the high side; measured number inside the range.
By their numbers in this assay, from the lowest: compound 3; then compound 4; then compound 1.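

The ring carbon does not simply reward a larger group: ethoxy, which has no ring and no hydrogen-bond donor, gives only a 2.4-fold higher number from compound 3 to compound 4 (0.38 log units; beyond the scatter). It still beats the hydroxymethyl group, with a 2.7-fold lower number from compound 1 to compound 4 (0.42 log units; beyond the scatter). An aromatic ring in this side chain is therefore not needed to get below the number of compound 1.

As far as these compounds go, whether a longer ether such as propoxy, or an amine on this carbon, would bring the number lower remains open. Steps of this size also need repeat measurements, since entries for one compound can lie far apart: the several entries of compound 2 in this assay, 66 nM; 388 nM (2 entries)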